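Dichlorophenyl on the aromatic nitrogen: expectation for compound 3

A few compounds are considered here, and "the series" means these few. Any claim that something is new, unique, unknown or untested is made for them only; others in the source may bear on it.

Compound 1 `COc1cc2c(Oc3ccc(NC(=O)c4cn(-c5ccccc5)nn4)cc3F)ccnc2cc1OCCCN1CCCCC1` gives 210 nM in a functional assay on NCI-H460 cells (Homo sapiens) for cytotoxicity, read by MTT assay, with a stated time of 72 h; on this read-out lower numbers stand for stronger inhibition and higher numbers for weaker inhibition. Compound 2 `COc1cc2c(Oc3ccc(NC(=O)c4cn(-c5ccccc5)nn4)cc3F)ccnc2cc1OCCCN1CCC(C)CC1` gives 210 nM in this assay; the methyl on a saturated ring carbon brought no change at the digits printed from compound 1 to compound 2 (within the scatter), so compound 2 stands level with compound 1. Compound 3 `COc1cc2c(Oc3ccc(NC(=O)c4cn(-c5c(Cl)cccc5Cl)nn4)cc3F)ccnc2cc1OCCCN1CCC(C)CC1` carries 2,6-dichlorophenyl in place of phenyl on an aromatic nitrogen. Going by the values given here, the single measured step concerns the saturated ring, not the aromatic ring on the aromatic nitrogen, so no measured step bears on this change and no direction can be read from the series. Compound 3 is therefore expected near 200 nM in this assay, within 60 nM to 700 nM. The expected step is a 1.1-fold lower number from compound 2 to compound 3 (0.02 log units; within the scatter), a wide range reflecting the absence of a comparable step.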

Compound 3, half-maximal inhibitory concentration: 270 nM
Compound 3: middle estimate off by 1.4-fold (0.13 log units), on the low side; low and high end bracket the measured number.
By their numbers in this assay, from the lowest: compounds 1, 2 and 3 (each within the scatter of the next).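

In this assay the change to 2,6-dichlorophenyl on the aromatic nitrogen gives a 1.3-fold higher number from compound 2 to compound 3 (0.11 log units; within the scatter) and so stays within the scatter. Going by these compounds alone, the earlier compounds varied only the saturated ring, so this is the first reading on the aromatic ring at this position, and it shows that two chlorine atoms can be added there with no change beyond the scatter. Nothing available accounts for this result.

Still open, as far as these compounds go, is whether a single chlorine or a methoxy on this phenyl, or a cyclohexyl in its place, would hold the number in this assay as well. Also open, from the compounds shown here alone, is whether the 2,6-dichlorophenyl would read the same with the unsubstituted piperidine of compound 1.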